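Moving an Amino Group in a Sulfonyl Series

The compounds below may be only part of what the source reports. "The series", "measured", "known", "first", "only" and "open" are said of these compounds alone.

Measured in a functional assay on K562 cells (Homo sapiens) for inhibition, read by trypan blue exclusion, with a stated time of 72 h (on this read-out lower numbers stand for stronger inhibition and higher numbers for weaker inhibition), so far
Compound 1 `Cn1c(=O)c(S(=O)(=O)Nc2ccc(F)cc2F)cc2cnc(Nc3ccc4[nH]ccc4c3)nc21` gives 5000 nM
Compound 2 `Cn1c(=O)c(S(=O)(=O)c2ccc(N)cc2F)cc2cnc(Nc3ccc4[nH]ccc4c3)nc21` gives 1500 nM

Compound 2 at 1500 nM holds the lower of the two numbers. Compound 3 `Cn1c(=O)c(S(=O)(=O)c2ccc(F)cc2N)cc2cnc(Nc3ccc4[nH]ccc4c3)nc21` carries 2-amino-4-fluorophenyl in place of 4-amino-2-fluorophenyl on a sulfonyl sulfur and is still unmeasured. Going by the values given here, the only measured step of a 3.3-fold lower number from compound 1 to compound 2 (0.52 log units; beyond the scatter) was modest and involved a different change, so it offers only a rough guide to size. Among the compounds with values here, no measured step makes this swap, so no step beyond the scatter is expected in this assay here. The estimated step of a 1.3-fold higher number from compound 2 to compound 3 (0.12 log units; within the scatter) stays small. Compound 3 is estimated at 2000 nM with an expected range from 600 nM to 6500 nM in this measurement.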

Compound 3, half-maximal inhibitory concentration: 2000 nM
For compound 3 middle estimate and measured number coincide at the digits printed; measured number inside the range.
By their numbers in this assay, from the lowest: compounds 2 and 3 (each within the scatter of the next); then compound 1.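

In this assay, the two aminofluorophenyl groups on the sulfonyl sulfur cannot be told apart, with a 1.3-fold higher number from compound 2 to compound 3 (0.12 log units; within the scatter). The step of a 2.5-fold lower number from compound 1 to compound 3 (0.40 log units; beyond the scatter) shows that compound 3, like compound 2, stands apart from compound 1, which carries (2,4-difluorophenyl)amino at this place. Nothing available explains these numbers. The compounds shown leave open what a carboxylic acid in place of the amino group on this phenyl ring would do, and whether a ring carrying fluorine with no amino group would match compound 3.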